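A few compounds are considered here, and "the series" means these few. Any claim that something is new, unique, unknown or untested is made for them only; others in the source may bear on it.

Compound 1 `O=S(=O)(Nc1ccc(-c2nc3ccccc3o2)cc1)c1ccccc1F`: > 100000 nM
Compound 2 `O=S(=O)(Nc1ccc2oc(-c3ccccc3)nc2c1)c1ccc(Cl)s1`: > 100000 nM

Both compounds were tested in an ADME assay on HEK293 cells (Homo sapiens) for cytotoxicity, read by resazurin assay, with a stated time of 48 h; on this read-out higher numbers stand for lower toxicity in this test and lower numbers for higher toxicity in this test. For compound 1 the result is a limit of the assay, > 100000 nM, and not a measured number. For compound 2 the result is likewise a limit of the assay, > 100000 nM. Compound 1 therefore stands at the limit of > 100000 nM in this assay, at which 2 of the 2 values shown sit, so no number ranks it against any other compound here.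

Compound 3 `COc1cccc(S(=O)(=O)Nc2ccc(-c3nc4ccccc4o3)cc2)c1` has not yet been measured. It differs from compound 1 in one place: 3-methoxyphenyl in place of 2-fluorophenyl on a sulfonyl sulfur. Among the compounds with values here, no two measured compounds differ in a single place, so no measured step is available. The step that the limit leaves unreadable from compound 1 to compound 3 is expected to be none beyond the usual scatter, because compound 1 already sits at the limit > 100000 nM in this assay. Compound 3 is expected to give about 150000 nM, somewhere between 50000 nM and 500000 nM, and most likely to be reported again only as a limit.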

Compound 3, half-maximal cytotoxic concentration: > 100000 nM
Compound 3 gave a limit, no number; the forecaster's own chance of this, stated with the estimate: 80%; the middle value does not contradict the limit.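

In this assay, within the data shown here, compound 3 gave only a limit, as compound 1 did, so no step between compound 1 and compound 3 can be read: the limit of > 100000 nM in this assay, at which 3 of the 3 values shown sit. The compounds shown leave open how their true cytotoxic concentrations compare, and whether any change on the sulfonyl sulfur would alter them.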